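Lengthening the chain on compound 2's ring amine

A few compounds are considered here, and "the series" means these few. Any claim that something is new, unique, unknown or untested is made for them only; others in the source may bear on it.

Of the compounds shown here, three have been measured so far in a functional assay on ileum for inhibition of histamine H1 receptor (Cavia porcellus); on this read-out lower numbers stand for stronger inhibition and higher numbers for weaker inhibition. Compound 1, with the structure `CCCN1CCCN(c2nc3ccccc3n2CCOCC)CC1`, gives 8.4 nM in this assay. Compound 2, with the structure `CCOCCn1c(N2CCN(CC)CC2)nc2ccccc21`, gives 18 nM in this assay. Compound 3, with the structure `CCCCCCCn1c(N2CCN(C)CC2)nc2ccccc21`, gives 150 nM in this assay. Compound 2 therefore stands at the second highest of the three numbers: compound 1 sits below it by a gap beyond the scatter, and compound 3 sits above it by a larger gap, also beyond the scatter. Each of these pairs differs in more than one place, so no single change can be read from them.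

The step under consideration leads from compound 2 to compound 4, whose structure is `CCCCCN1CCN(c2nc3ccccc3n2CCOCC)CC1`. The change is propyl in place of hydrogen on a saturated chain carbon, two bonds along the chain from an amine nitrogen in a ring. Going by the values given here, the only other compound carrying a longer chain, compound 3, differs from compound 2 in two places at once, so its higher number does not show what this chain alone does.

Among the compounds with values here, with no matching pair available, a step of modest size, toward a somewhat higher number, is expected. For compound 4 the estimated result in this assay is 30 nM, with a range from 8 nM to 120 nM. This estimate means an expected step of a 1.7-fold higher number from compound 2 to compound 4 (0.22 log units; within the scatter).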

Compound 4, half-maximal inhibitory concentration: 30 nM
Compound 4: middle estimate and measured number agree at the digits printed, within the range that was stated.
By their numbers in this assay, from the lowest: compound 1; then compounds 2 and 4 (each within the scatter of the next); then compound 3.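

In this assay, going by these compounds alone, putting propyl in place of hydrogen on a saturated chain carbon, two bonds along the chain from an amine nitrogen in a ring, turns ethyl into pentyl and gives a 1.7-fold higher number from compound 2 to compound 4 (0.22 log units; within the scatter) as the first reading of this one change on its own. A step of this size cannot be told apart from the differences seen between repeated measurements, so at this position the added 3 carbon atoms leave no clear mark on inhibition of the receptor in this assay, and ethyl and pentyl cannot be ranked against each other. Nothing measured on these compounds offers an explanation for this result.

Within the data shown here, this single pair covers only two chain lengths on one shared core and says nothing about whether a still longer chain, such as octyl, would keep the number in the same region. It also leaves open what would happen if the chain carried something other than plain carbon and hydrogen, such as a carboxylic acid or a phenyl ring at its far end.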